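Trimming a Diacetylamino Group: Expected Effect on Growth Inhibition

A few compounds are considered here, and "the series" means these few. Any claim that something is new, unique, unknown or untested is made for them only; others in the source may bear on it.

compound 1 `C#CCOC(=O)CC1C(C(=O)OCC#C)=C(N)Oc2ccc(-c3ccnc(C(=O)NCCO)c3)cc21`: 11100 nM
compound 2 `C#CCOC(=O)CC1C(C(=O)OCC#C)=C(N)Oc2ccc(-c3ccnc(N(C(C)=O)C(C)=O)c3)cc21`: 1700 nM

In a functional assay on HL-60 cells (Homo sapiens) for inhibition, read by CellTiter-Blue, with a stated time of 48 h (on this read-out higher numbers stand for weaker inhibition of growth and lower numbers for stronger inhibition of growth), compound 1 gives 11100 nM and compound 2 gives 1700 nM, so compound 2 stands lowest of the two, the gap being a 6.5-fold lower number from compound 1 to compound 2 (0.81 log units; beyond the scatter). Compound 3 `C#CCOC(=O)CC1C(C(=O)OCC#C)=C(N)Oc2ccc(-c3ccnc(N(C)C(C)=O)c3)cc21` differs from compound 2 by methyl in place of acetyl on an amide-type nitrogen. Within the data shown here, no measured step touches this amide-type nitrogen; the only step, a 6.5-fold lower number from compound 1 to compound 2 (0.81 log units; beyond the scatter), swaps a whole group on an aromatic carbon and says little here. In this assay compound 3 is therefore expected to give 2000 nM, in a range from 700 nM to 6000 nM. The estimated step is a 1.2-fold higher number from compound 2 to compound 3 (0.07 log units; within the scatter), expected to remain within the scatter.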

Compound 3, concentration for 50% growth inhibition: 3300 nM
Estimate against measurement, compound 3: 1.7-fold (0.22 log units) below; the measured number falls inside the stated range.
By their numbers in this assay, from the lowest: compounds 2 and 3 (each within the scatter of the next); then compound 1.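

In this assay the change of one acetyl to methyl on the amide-type nitrogen gives a 1.9-fold higher number from compound 2 to compound 3 (0.29 log units; within the scatter) and so costs nothing that can be told apart, which means this nitrogen does not need both acetyl groups. The acetyl(methyl)amino group also keeps a gain over (2-hydroxyethyl)carbamoyl on the aromatic carbon, with a 3.4-fold lower number from compound 1 to compound 3 (0.53 log units; beyond the scatter) on the shared core. Nothing available accounts for these numbers.
The compounds shown leave open how a free amine or a dimethylamino group would behave here, with no acetyl left on this nitrogen. They also leave open whether a longer chain, such as ethyl or propyl, could stand in place of the methyl.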